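Moving the Bromine Around a Phenyl Group

The source may hold more compounds than are shown below. What is called first, only, known or untested is meant among the compounds shown, and "the series" means these compounds.

For the measured compounds named here, in a functional assay on MCF7 cells (Homo sapiens) for cytotoxicity, read by MTT assay, with a stated time of 96 h (a lower number here means a stronger inhibitor, a higher number a weaker inhibitor), compound 2 `COc1cc(C(=O)c2cn(-c3ccccc3)cc2-c2ccccc2Br)cc(OC)c1OC` gives 190 nM, the lower of the two numbers measured so far. Compound 1 `COc1cc(C(=O)c2cn(-c3ccccc3)cc2-c2cccc(Cl)c2)cc(OC)c1OC` gives 540 nM. The next compound, compound 3 `COc1cc(C(=O)c2cn(-c3ccccc3)cc2-c2cccc(Br)c2)cc(OC)c1OC`, carries 3-bromophenyl in place of 2-bromophenyl on an aromatic carbon of the shared core: 3-bromophenyl in place of 2-bromophenyl on an aromatic carbon. Going by the values given here, only one measured step bears on this change. That step, a 2.8-fold lower number from compound 1 to compound 2 (0.45 log units; beyond the scatter), is modest but beyond the scatter, and it alters the halogen and its place on the phenyl group together, so the two effects cannot be separated. Compound 3 has the same 3-substituted pattern as the 3-chlorophenyl of compound 1, which gives 540 nM, so a return towards that number is expected. The expected change in this assay is a 2.4-fold higher number from compound 2 to compound 3 (0.37 log units; beyond the scatter), of similar size to the measured step. For compound 3 the estimated value is 450 nM, with an expected range of 170 nM to 1200 nM.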

Compound 3, half-maximal inhibitory concentration: 950 nM
Beside the measured number, compound 3's estimate is 2.1-fold (0.32 log units) below it, within the range that was stated.
By their numbers in this assay, from the lowest: compound 2; then compounds 1 and 3 (each within the scatter of the next).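

Moving the bromine alone, with the same atoms joined differently, gives a 5.0-fold higher number from compound 2 to compound 3 (0.70 log units; beyond the scatter) in this assay. The earlier step changed the halogen and its place together, whereas this one shows that place alone can shift the number beyond the scatter. Exchanging the halogen without moving it gives a 1.8-fold higher number from compound 1 to compound 3 (0.25 log units; within the scatter), so bromo and chloro cannot be told apart in the 3-substituted pattern, and among these three compounds the difference follows where the halogen sits, not which halogen it is; no measurement at hand explains why the place matters.

Still open, as far as these compounds go, is whether 2-bromophenyl owes its lower number to the bromine itself or whether a methoxy group or an amine at that place would serve as well. A plain phenyl group without any halogen would also show whether the bromine helps at all.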